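This account rests on a few compounds, and the source may have more. Where it says the series, first, only, none or still open, it means among the compounds named here.

Measured in a functional assay on MGC-803 cells (Homo sapiens) for cytotoxicity, read by MTT assay, with a stated time of 48 h; a lower number here means a stronger inhibitor, a higher number a weaker inhibitor:
- compound 1 `CC1=NN(C(=O)CCl)C(c2cc(Br)ccc2O)C1`: 13500 nM
- compound 2 `CC1=NN(S(=O)(=O)c2ccc([N+](=O)[O-])cc2)C(c2cc(Br)cc(Br)c2O)C1`: 40100 nM
- compound 3 `O=C(CCl)N1N=C(c2cc3ccccc3oc2=O)CC1c1ccccc1`: 2020 nM

Compound 3 stands lowest of the three at 2020 nM, and its gaps to compound 1 and to compound 2 both lie beyond the scatter. Compound 4 `CC(C)(C)NCC(=O)N1N=C(c2cc3ccccc3oc2=O)CC1c1ccccc1` differs from compound 3 by one change: (tert-butyl)amino in place of chloro on a saturated chain carbon bound to a carbonyl carbon. Going by the values given here, no measured pair shows this change, so the expectation is loose. In this assay a moderate move towards a weaker inhibitor is expected, at the edge of the scatter or slightly beyond it. The expected step is a 2.2-fold higher number from compound 3 to compound 4 (0.35 log units; beyond the scatter). The estimate for compound 4 is 4500 nM, with an expected range of 900 nM to 22000 nM.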

Compound 4, half-maximal inhibitory concentration: 15400 nM
For compound 4 the middle estimate is 3.4-fold (0.53 log units) below the measured one, and the stated range covers the measured number.
By their numbers in this assay, from the lowest: compound 3; then compounds 1 and 4 (each within the scatter of the next); then compound 2.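

On the saturated chain carbon bound to a carbonyl carbon, (tert-butyl)amino in place of chloro gives a 7.6-fold higher number from compound 3 to compound 4 (0.88 log units; beyond the scatter) in this assay. This is the only one-place step among the compounds shown, and it shows that the number in this assay responds to the group at this position, with chloro the better of the two groups compared. No measured evidence bears on what lies behind the step. Going by these compounds, it remains open whether a smaller amine such as methylamino, or a cyclic amine such as morpholine, would stay closer to compound 3 than compound 4 does.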